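A few compounds are considered here, and "the series" means these few. Any claim that something is new, unique, unknown or untested is made for them only; others in the source may bear on it.

In an assay on isolated protein for inhibition of MAP kinase-activated protein kinase 2 (Homo sapiens), read by mobility shift assay, tested at 30 uM (on this read-out higher numbers stand for more inhibition at the one concentration tested (going by the name of the read-out) and lower numbers for less inhibition), compound 3 `CC(C)(C)c1cc2nn(-c3ccccc3)c(N)c2c(=O)[nH]1` gives 6%, the lowest of the three numbers in hand. Compound 2 `Cc1cc2c(c(N)nn2C)c(N2CCCCC2)n1` gives 7%, a number within the scatter of compound 3, so the two cannot be ordered. Compound 1 `Nc1n[nH]c2cc(-c3ccncc3)[nH]c(=O)c12` gives 37%, beyond the scatter and well above compound 3. Compound 4 `Nc1c2c(=O)[nH]c(-c3ccccn3)cc2nn1-c1ccccc1` has not yet been measured; it differs from compound 3 by pyridin-2-yl in place of tert-butyl on an aromatic carbon. Within the data shown here, no step between measured compounds matches this change, so its size is open. Among the measured compounds shown here, a modest rise in this assay is expected, as the one number beyond the scatter, that of compound 1, shows room upward. Compound 4 is estimated at 18%, with a range from 3% to 40%, an expected step of a number 12 percentage points higher from compound 3 to compound 4 (beyond the scatter).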

Compound 4, a percentage reported as inhibition, at one concentration (the size of the read-out at that concentration, not a potency): 4%
For compound 4 the middle estimate is 14 percentage points above the measured one, within the range that was stated.
By their numbers in this assay, from the lowest: compounds 4, 3 and 2 (each within the scatter of the next); then compound 1.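

In this assay, pyridin-2-yl in place of tert-butyl on the aromatic carbon next to the ring nitrogen gives a number 2 percentage points lower from compound 3 to compound 4 (within the scatter). At this position, then, the read-out does not separate a six-membered aromatic ring carrying a hydrogen-bond acceptor from a group with neither, and compound 4 stays low at 4%. No measured property of either group bears on this result. From the compounds shown here alone, what a carboxylic acid or a morpholine ring would give on this carbon remains open, as does whether any group here can raise the number beyond the scatter.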